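A few compounds are considered here, and "the series" means these few. Any claim that something is new, unique, unknown or untested is made for them only; others in the source may bear on it.

Compound 1 `C/C(=N\Nc1nc(-c2ccccc2)cs1)c1sc(C)nc1C` gives > 100 ug/mL in a toxicity assay on THP-1 cells (Homo sapiens) for cytotoxicity, read by MTT assay (a higher number here means a weaker inhibitor of growth, a lower number a stronger inhibitor of growth), a limit of the assay. Compound 2 `C/C(=N\Nc1nc(-c2ccc(F)cc2)cs1)c1sc(C)nc1C` gives > 100 ug/mL in this assay, likewise a limit. Compound 2 thus stands at the limit, with no number of its own. The step that the two limits leave unreadable from compound 1 to compound 2 cannot be sized, since both values sit at the limit of > 100 ug/mL in this assay, at which 2 of the 2 values shown sit. Compound 3 `C/C(=N\Nc1nc(-c2ccc(Cl)cc2)cs1)c1sc(C)nc1C` differs from compound 2 by chloro in place of fluoro on an aromatic carbon. No measured step bears on this change, and the one shown step was itself unreadable. The step of a number no higher from compound 2 to compound 3 (the limit leaves the size open) is therefore expected to be none beyond the scatter. Compound 3 is expected to give 100 ug/mL, with a range of 50 ug/mL to 200 ug/mL, most likely again reported only as a limit.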

Compound 3, concentration for 50% growth inhibition: > 100 ug/mL
Compound 3: no number, only a limit; the forecaster's own chance of this, stated with the estimate: 85%; the middle value lies on the limit itself.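

Compound 3 gives > 100 ug/mL, again a limit, so its steps from compound 1 and from compound 2 cannot be read. The compounds shown leave open whether hydrogen, fluoro and chloro differ at all in this assay: the limit of > 100 ug/mL in this assay, at which 3 of the 3 values shown sit.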